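A methoxy swap on a weak inhibitor

This account rests on a few compounds, and the source may have more. Where it says the series, first, only, none or still open, it means among the compounds named here.

Compound 1 `CC(C)=CCc1c(O)cc(/C=C/c2ccc3c(c2)[C@H](c2cc(O)c(CC=C(C)C)c(O)c2)[C@@H](c2ccc(O)cc2)O3)cc1O` gives 47000 nM
Compound 2 `CC(C)=CCc1c(O)cc([C@@H](Oc2ccc(/C=C/c3cc(O)c4c(c3)OC(C)(C)CC4)cc2)[C@@H](C)c2ccc(O)cc2)cc1O` gives 150000 nM

In a functional assay for inhibition, read by spectrophotometry, with a stated time of 30 min (a lower number here means a stronger inhibitor, a higher number a weaker inhibitor), compound 2 gives 150000 nM and holds the higher of the two numbers, making it the weaker inhibitor. On the same read-out compound 1 gives 47000 nM. The gap between the two compounds lies beyond the scatter. Compound 3 `CO[C@@H](c1ccc(O)cc1)[C@H](Oc1ccc(/C=C/c2cc(O)c3c(c2)OC(C)(C)CC3)cc1)c1cc(O)c(CC=C(C)C)c(O)c1` differs from compound 2 in one place: the change methoxy in place of methyl on a saturated chain carbon bound to an aromatic carbon and a saturated chain carbon puts methoxy in place of methyl on a saturated chain carbon bound to an aromatic carbon and a saturated chain carbon. Going by the values given here, no measured pair shows this change, and no step beyond the scatter is expected in this assay with the estimated step of a 1.3-fold lower number from compound 2 to compound 3 (0.10 log units; within the scatter) leaning slightly towards a lower number. Compound 3 is expected at 120000 nM within an estimated range from 45000 nM to 300000 nM overall.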

Compound 3, half-maximal inhibitory concentration: 185000 nM
Compound 3: the middle estimate sits 1.5-fold (0.19 log units) below what was measured, and the stated range covers the measured number.
By their numbers in this assay, from the lowest: compound 1; then compounds 2 and 3 (each within the scatter of the next).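

In this assay, methoxy in place of methyl on a saturated chain carbon bound to an aromatic carbon and a saturated chain carbon gives a 1.2-fold higher number from compound 2 to compound 3 (0.09 log units; within the scatter). This first one-place comparison therefore shows that the swap leaves the number within the scatter, and both compounds remain weak inhibitors. Nothing measured here explains this result. Going by these compounds, only methyl and methoxy are seen on this carbon, and whether an amine or a carboxylic acid there would shift the number remains open.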